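Methyl on the amine nitrogen of compound 1

The compounds below may be only part of what the source reports. "The series", "measured", "known", "first", "only" and "open" are said of these compounds alone.

In an ADME assay on TERT-RPE1 cells (Homo sapiens) for cytotoxicity, read by MTT assay, with a stated time of 72 h (on this read-out higher numbers stand for weaker inhibition and lower numbers for stronger inhibition), compound 1 `C=C1CN/C(=N/c2ccccc2)S1` gives > 100000 nM as a limit and not a number. Compound 3 `COc1ccc(/C=C2\S/C(=N\c3ccc(Cl)cc3)N(C)C2=O)cc1` gives > 100000 nM as a limit too. Compound 1 therefore stands at the limit of > 100000 nM in this assay, at which 2 of the 3 values shown sit, with no number to step from. Only compound 2 `COc1ccc(/C=C2/CN(C)/C(=N/c3ccc(C(C)(C)C)cc3)S2)cc1` gives a number, at 23500 nM in this assay as read here.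

Compound 4 `C=C1CN(C)/C(=N/c2ccccc2)S1` differs from compound 1 by methyl in place of hydrogen on an amine nitrogen in a ring with methyl in place of hydrogen on an amine nitrogen in a ring. For the measured compounds named here, no measured pair shows this change. Going by the values given here, a modest step towards stronger inhibition is expected at most, perhaps none beyond the scatter, with compound 2 at 23500 nM as the only number available. The estimated move is an at least 1.2-fold lower number from compound 1 to compound 4 (0.09 log units; that floor lies within the scatter) and no larger. In this assay the expected value for compound 4 is 80000 nM with an estimated range of 30000 nM to 200000 nM for now.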

Compound 4, half-maximal inhibitory concentration: > 100000 nM
Compound 4 ended at the assay's limit; the forecaster's own chance of this, stated with the estimate: 60%; middle value at least 1.2-fold (0.09 log units) from the limit.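

No step can be read from compound 1 to compound 4, as both values are limits and not numbers: the limit of > 100000 nM in this assay, at which 3 of the 4 values shown sit.
In this assay, going by these compounds, the size of any change from methyl in place of hydrogen on an amine nitrogen in a ring stays open.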